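Halogen swap on the N-aryl group of the quinolone series

The source may hold more compounds than are shown below. What is called first, only, known or untested is meant among the compounds shown, and "the series" means these compounds.

Compound 3 `Cn1ccc2c(Oc3ccc(NC(=O)c4cn(-c5ccc(Cl)cc5)c5ccccc5c4=O)cc3F)ccnc21` stands lowest of the three numbers measured in a functional assay on A549 cells (Homo sapiens) for inhibition, read by MTT assay, with a stated time of 72 h (a higher number here means a weaker inhibitor, a lower number a stronger inhibitor), where compound 3 gives 250 nM. Compound 2 `Cn1ccc2c(Oc3ccc(NC(=O)c4cn(-c5ccc(F)cc5)c5ccccc5c4=O)cc3F)ccnc21` carries fluoro where compound 3 carries chloro, and compound 2 gives 1460 nM in this assay. Compound 1 `O=C(Nc1ccc(Oc2ccnc3[nH]ccc23)cc1)c1cn(-c2ccc(F)c(Cl)c2)c2ccccc2c1=O` differs in more than one place and gives 4810 nM in this assay. For the measured compounds named here, the one step measured in one place is a 5.8-fold lower number from compound 2 to compound 3 (0.77 log units; beyond the scatter). Compound 4 `Cn1ccc2c(Oc3ccc(NC(=O)c4cn(-c5ccc(Br)cc5F)c5ccccc5c4=O)cc3F)ccnc21` is not yet measured. It differs from compound 3 by 4-bromo-2-fluorophenyl in place of 4-chlorophenyl on an aromatic nitrogen. Going by the values given here, the step from compound 2 to compound 3 bears on the exchange of one para halogen for a heavier one, and the ortho fluorine has no counterpart among the measured compounds. For compound 4 the expectation is a step of a 1.3-fold lower number from compound 3 to compound 4 (0.10 log units; within the scatter), which is a small change toward a lower number or none beyond the scatter, resting on a 5.8-fold lower number from compound 2 to compound 3 (0.77 log units; beyond the scatter). The estimate for compound 4 is therefore 200 nM, within 70 nM to 600 nM.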

Compound 4, half-maximal inhibitory concentration: 1520 nM
Compound 4: middle estimate off by 7.6-fold (0.88 log units), on the low side; the whole stated range lies below it.
By their numbers in this assay, from the lowest: compound 3; then compounds 2 and 4 (each within the scatter of the next); then compound 1.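

In this assay the position on the aromatic nitrogen follows no simple trend with halogen size: the change to 4-bromo-2-fluorophenyl gives a 6.1-fold higher number from compound 3 to compound 4 (0.78 log units; beyond the scatter) and runs against the earlier step from fluoro to chloro. Set against 4-fluorophenyl, the same group gives a 1.0-fold higher number from compound 2 to compound 4 (0.02 log units; within the scatter) and so no separation between the two. Of the three aryl groups on this shared core, only 4-chlorophenyl stands apart, and the gain it brought does not carry over to the bromo and fluoro pair.

The bromine and the added fluorine enter together, so the compounds shown do not say which of them carries the step. As far as these compounds go, how an unsubstituted phenyl, or a methoxy or an amine on this aryl ring, would read also remains open. No data at hand explain these steps.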